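The source may hold more compounds than are shown below. What is called first, only, known or untested is meant among the compounds shown, and "the series" means these compounds.

Going by the values given here, compound 2 `CC(=O)Nc1cc(-c2ccc(OC[C@@H](N)CC(C)C)cc2)ccn1` gives 0.9 nM in an assay on brain (strain C57BL6) for displacement of a labelled ligand from AP2-associated protein kinase 1 (Mus musculus), read by scintillation counting, with a stated time of 1 h (on this read-out lower numbers stand for stronger inhibition and higher numbers for weaker inhibition), the higher of the two numbers measured so far; its nearest neighbour, compound 1 `CC(=O)Nc1cc(-c2ccc(OC[C@@H](N)CC(C)C)c(F)c2)ccn1`, gives 0.52 nM, and the step of a 1.7-fold higher number from compound 1 to compound 2 (0.24 log units; within the scatter) lies within the scatter. Compound 3 `CC(=O)Nc1cc(-c2ccc(OC[C@@H](N)CC(C)C)c(OC(F)(F)F)c2)ccn1` has not yet been measured. It differs from compound 2 by trifluoromethoxy in place of hydrogen on an aromatic carbon, the new group entering on an aromatic carbon ortho to the (2-amino-4-methylpentyl)oxy group and meta to a large group. Among the compounds with values here, the only measured step that bears on this change is a 1.7-fold higher number from compound 1 to compound 2 (0.24 log units; within the scatter), which shows that exchanging a fluoro substituent for hydrogen at that aromatic carbon left the number essentially unchanged. Trifluoromethoxy is a larger group than fluoro, so no direct precedent exists, and only a small shift, in either direction and likely within the scatter, is expected in this assay. Compound 3 is therefore estimated to give 1.5 nM, with a range from 0.4 nM to 6 nM. That estimate corresponds to an expected step of a 1.7-fold higher number from compound 2 to compound 3 (0.22 log units; within the scatter).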

Compound 3, inhibition constant: 0.04 nM
The estimate for compound 3 lay 38-fold (1.57 log units) above the measured number, outside the stated range (below it).
By their numbers in this assay, from the lowest: compound 3; then compounds 1 and 2 (each within the scatter of the next).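

In this assay, this aromatic carbon ortho to the (2-amino-4-methylpentyl)oxy group proves highly sensitive to its substituent: trifluoromethoxy in place of hydrogen gives a 23-fold lower number from compound 2 to compound 3 (1.35 log units; beyond the scatter), a large step, whereas the earlier exchange between fluoro and hydrogen stayed within the scatter. Fluoro at this carbon therefore does not predict the outcome, and trifluoromethoxy in place of fluoro also gives a large step, a 13-fold lower number from compound 1 to compound 3 (1.11 log units; beyond the scatter). No measurement is available to explain why trifluoromethoxy differs so strongly from fluoro.

From the compounds shown here alone, it remains open whether a methoxy, trifluoromethyl or chloro group at the same carbon would give a similarly low number, and so how much depends on the oxygen or on the fluorines. Also open, going by these compounds, is whether the step would persist with a different chain in place of the (2-amino-4-methylpentyl)oxy group.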